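Fluorine at the para position: compound 3 to compound 4

The compounds below may be only part of what the source reports. "The series", "measured", "known", "first", "only" and "open" are said of these compounds alone.

Compound 1, `Fc1ccc(Nc2[nH]cnc3ncnc2-3)cc1`, gives 52%.
Compound 2, `Cn1cnc2c(SCc3ccccc3)ncnc21`, gives 1%.
Compound 3, `Clc1ncnc2c1ncn2Cc1ccccc1`, gives 3%.

These three compounds were measured in an assay on isolated protein for inhibition of Rho-associated protein kinase 1 (Homo sapiens), tested at 30 uM; a higher number here means more inhibition at the concentration tested (going by the name of the read-out), a lower number less inhibition. Compound 3 stands second highest of the three numbers, but its nearest neighbour is compound 2, whose value lies within the usual scatter of the value of compound 3, so the two cannot be told apart. The furthest number is that of compound 1, which lies far above compound 3 and beyond the scatter.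

Compound 4, `Fc1ccc(Cn2cnc3c(Cl)ncnc32)cc1`, has not yet been measured in this assay. It differs from compound 3 by one change: fluoro in place of hydrogen on an aromatic carbon. For the measured compounds named here, no step between measured compounds of this kind has been seen, so the expectation rests on compound 3 alone. A change of one heavy atom para to a large group is expected to leave the number close to where compound 3 stands, with no step beyond the scatter in this assay.

The estimated step from compound 3 to compound 4 is a number 2 percentage points higher from compound 3 to compound 4 (within the scatter). For compound 4 the expected value is 5%, within a range from 0% to 20%.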

Compound 4, a percentage reported as inhibition, at one concentration (the size of the read-out at that concentration, not a potency): 0%
Compound 4: middle estimate off by 5 percentage points, on the high side; the measured number falls inside the stated range.
By their numbers in this assay, from the lowest: compounds 4, 2 and 3 (each within the scatter of the next); then compound 1.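

In this assay, for the compounds shown here, fluoro in place of hydrogen on an aromatic carbon, para to a large group, gives the first step that can be read at this position: a number 3 percentage points lower from compound 3 to compound 4 (within the scatter). Compound 3 at 3% and compound 4 at 0% therefore cannot be told apart, so at this position on the six-membered aromatic ring this single swap leaves no mark that the read-out can separate from repeat scatter, though both numbers sit close to the bottom of the percentage scale, and a single pair this low says little about how the same swap would read on a compound with a much higher number. No measurement at hand speaks to why the pair reads as it does.

On these data alone, whether a larger group at the same place, such as a methoxy group, an amine or a carboxylic acid, would lift the number beyond the scatter remains open. Also open, as far as these compounds go, is whether replacing the chloro group on the shared core with an amine, while the fluoro group stays in place, would produce a step that can be read.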